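Hydroxy to methoxy: from compound 1 to compound 3

This account rests on a few compounds, and the source may have more. Where it says the series, first, only, none or still open, it means among the compounds named here.

- compound 1 `O=C(/C=C(/C=C/c1ccc(O)cc1)NCCCO)/C=C/c1ccc(O)cc1` with 57300 nM as its value
- compound 2 `COCCNC(=C\C(=O)/C=C/c1ccc(O)c(OC)c1)/C=C/c1ccc(O)c(OC)c1` with >= 100000 nM as a limit of the assay, not a number

For the measured compounds named here, in a toxicity assay on EA.hy 926 cells (Homo sapiens) for cytotoxicity, read by MTT assay, with a stated time of 48 h (on this read-out lower numbers stand for stronger inhibition and higher numbers for weaker inhibition), compound 1 gives 57300 nM as the only true number so far, so it has no measured neighbour to be ranked against. Compound 2 stands at >= 100000 nM as a limit and not a number.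

Compound 3 `COCCCNC(=C\C(=O)/C=C/c1ccc(O)cc1)/C=C/c1ccc(O)cc1` has not yet been measured. It differs from compound 1 in one place, with hydroxy changed to methoxy, that is, methyl in place of hydrogen on an oxygen on a saturated carbon. The full count reads methyl in place of hydrogen on an oxygen on a saturated carbon for this difference.

Going by the values given here, no two measured compounds differ in one place only, so no measured step gives a size for this change. The expectation in this assay is therefore no step beyond the usual scatter, with neither direction favoured. The expected 1.0-fold higher number from compound 1 to compound 3 (0.02 log units; within the scatter) is an estimate made on that basis. Compound 3 is estimated at 60000 nM with an expected range from 28000 nM to 100000 nM for a repeated measurement.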

Compound 3, half-maximal inhibitory concentration: 81900 nM
Estimate against measurement, compound 3: 1.4-fold (0.14 log units) below; the range from low to high includes it.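

In this assay, methyl in place of hydrogen on an oxygen on a saturated carbon gives a 1.4-fold higher number from compound 1 to compound 3 (0.16 log units; within the scatter). For the compounds shown here, this is the first measured size for any single change, and it shows that going from hydroxy to methoxy at this position does not move the read-out beyond what repeated measurements would give; the hydrogen on that oxygen, and the hydrogen-bond donor count that goes with it, make no visible difference here. Compound 2 stays outside this comparison, since it differs from compound 1 in more than one place and its reading is a limit and not a number: the limit of >= 100000 nM in this assay, at which 1 of the 3 values shown sits.

One step at one position says nothing yet about how far this end of the chain can be altered before the read-out shifts beyond the scatter. An amine or a carboxylic acid in place of the hydroxy, or a longer chain carrying the same methoxy, remains an open case, and so does the question of whether this methyl would behave the same way on another part of the molecule.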